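The source may hold more compounds than are shown below. What is called first, only, known or untested is meant among the compounds shown, and "the series" means these compounds.

Series notes, step from compound 2 to compound 4.

Three ureas share one core. Compound 1 `O=C(Nc1cccc(-n2cc(-c3ccncc3)c(-c3cc(O)cc(Cl)c3)n2)c1)Nc1ccc(Cl)c(C(F)(F)F)c1` gives 100% in a functional assay on SK-MEL-28 cells (Homo sapiens) for inhibition, read by sulforhodamine B assay, with a stated time of 48 h, tested at 0.1 uM; a lower number here means a stronger effect, a higher number a weaker effect of the compound at the concentration tested. Compound 2 `COc1cc(Cl)cc(-c2nn(-c3cccc(NC(=O)Nc4ccc(Cl)c(C(F)(F)F)c4)c3)cc2-c2ccncc2)c1` gives 106% in this assay, and compound 3 `COc1cc(Cl)cc(-c2nn(-c3cccc(NC(=O)Nc4cc(C(F)(F)F)cc(C(F)(F)F)c4)c3)cc2-c2ccncc2)c1` gives 102%. Within the data shown here, the only single-point step measured runs a number 6 percentage points higher from compound 1 to compound 2 (within the scatter). Compound 2 holds the highest of the three numbers shown, yet compound 3 and compound 1 both sit within the scatter of it, so nothing separates the three at this concentration: none of them inhibits the cells measurably.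

Compound 4 `COc1cc(Cl)cc(-c2nn(-c3cccc(NC(=O)c4cccc(C(F)(F)F)c4)c3)cc2-c2ccncc2)c1` is not yet measured. It differs from compound 2 by 3-(trifluoromethyl)phenyl in place of (4-chloro-3-(trifluoromethyl)phenyl)amino on a carbonyl carbon. Among the measured compounds shown here, no measured step covers this change; the urea is kept in all three measured compounds, so the set gives no direct read on replacing it. What the set does show is that neither the methyl on oxygen nor the choice of substituents on the terminal ring moved the number beyond the scatter.

Compound 4 is therefore expected to give 100% in this assay, within 85% to 112%. The expected step is a number 6 percentage points lower from compound 2 to compound 4 (within the scatter), that is, none beyond the scatter.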

Compound 4, a percentage reported as activity, at one concentration (the size of the read-out at that concentration, not a potency): 97%
The estimate for compound 4 lay 3 percentage points above the measured number, and the stated range covers the measured number.
By their numbers in this assay, from the lowest: compounds 4, 1, 3 and 2 (each within the scatter of the next).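

The urea is no longer a constant of the series: with 3-(trifluoromethyl)phenyl in place of (4-chloro-3-(trifluoromethyl)phenyl)amino on a carbonyl carbon, the read-out in this assay runs a number 9 percentage points lower from compound 2 to compound 4 (within the scatter). This change removes the amino nitrogen with its hydrogen-bond donor and also the ring chlorine, yet at this concentration it does not separate the amide from the urea, so the flat picture now extends to the group on the carbonyl carbon. No available data bear on why the read-out stays flat across this change.

On these data alone, it remains open whether a piperidine on that carbonyl carbon, or a longer alkyl chain in place of the 3-(trifluoromethyl)phenyl, would move the read-out beyond the scatter. As far as these compounds go, it also remains open whether the four compounds separate at any other concentration.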